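This account rests on a few compounds, and the source may have more. Where it says the series, first, only, none or still open, it means among the compounds named here.

Measured compounds:
compound 1, `O=S(=O)(c1ccc(F)c(Cl)c1)c1cnc2c(F)cccc2c1-c1cccc(Cl)c1`, 0.18 mL/min
compound 2, `O=S(=O)(c1cc(F)cc(F)c1)c1cnc2c(F)cccc2c1-c1ccccc1F`, 0.09 mL/min

Both compounds have been run in an ADME assay on microsomes from liver (Homo sapiens) for metabolic stability, tested at 2.5 uM; on this read-out lower numbers stand for slow clearance and higher numbers for fast clearance. Compound 1 gives 0.18 mL/min, and compound 2 gives 0.09 mL/min. Compound 2 sits at the low end of the two numbers, but its gap to compound 1 is within the usual scatter, so this assay does not separate the pair.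

Compound 3, `O=S(=O)(c1ccc(F)c(Cl)c1)c1cnc2c(F)cccc2c1-c1ccccc1F`, has not been measured yet. It differs from compound 2 in a single place: 3-chloro-4-fluorophenyl in place of 3,5-difluorophenyl on a sulfonyl sulfur. The group that enters is the same one found on the sulfonyl sulfur of compound 1, while the other aryl of compound 2 is kept. For the measured compounds named here, no step between measured compounds that differ in one place exists in this set, so no direction for this change has been established. Since compound 1, which carries the incoming group, gives 0.18 mL/min, any movement from compound 2 toward that number is expected to stay within the scatter.

Compound 3 is estimated at 0.13 mL/min, with a range from 0.06 mL/min to 0.28 mL/min. This estimate means an expected step of a 1.4-fold higher number from compound 2 to compound 3 (0.16 log units; within the scatter), not beyond the scatter.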

Compound 3, intrinsic clearance in a liver preparation (reported as CLH), per the amount of preparation that the assay uses: 1.39 mL/min
For compound 3 the middle estimate is 11-fold (1.03 log units) below the measured one, and the stated range ends below it.
By their numbers in this assay, from the lowest: compounds 2 and 1 (each within the scatter of the next); then compound 3.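

In this assay, the sulfonyl sulfur is a sensitive place when 2-fluorophenyl is kept on the core: 3-chloro-4-fluorophenyl in place of 3,5-difluorophenyl gives a 15-fold higher number from compound 2 to compound 3 (1.19 log units; beyond the scatter) as a large change. The incoming group does not set the level alone, since the same group is present in compound 1 and 2-fluorophenyl in place of 3-chlorophenyl on an aromatic carbon gives a 7.7-fold higher number from compound 1 to compound 3 (0.89 log units; beyond the scatter) as a further step beyond the scatter, so the read-out in this small set depends on which two aryl groups are paired. Nothing available explains why compound 3 stands apart from compound 1 and compound 2.

It remains open whether the same dependence holds for 3,5-difluorophenyl on the sulfonyl sulfur paired with 3-chlorophenyl on the aromatic carbon, a pairing outside the compounds shown. Also open, on these data alone, is how this read-out would respond to an amine or a carboxylic acid on the aryl group at the sulfonyl sulfur, and whether either would hold compound 3 nearer the level of compound 2.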